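The source may report more compounds than this note shows. Statements on the series, on what has been measured and on what is new or still open speak of the compounds shown alone.

Measured compounds:
- compound 1, `Cc1nnc(SCC(=O)c2ccccc2)n1N1C(=O)c2ccccc2C1=O`
- compound 2, `C#CCSc1nnc(CC)n1N1C(=O)c2ccccc2C1=O`
- compound 3, `CCc1nnc(SCc2ccccc2)n1N1C(=O)c2ccccc2C1=O`

In a functional assay on MKN-45 cells (Homo sapiens) for cytotoxicity, read by MTT assay, with a stated time of 48 h (a higher number here means a weaker inhibitor, a lower number a stronger inhibitor), compound 1 gives > 200000 nM, which is a limit of the assay and not a number. In this assay compound 2 gives > 200000 nM, again a limit. In this assay compound 3 gives > 200000 nM, also a limit. Compound 3 therefore stands only at a limit, as do the other two, all three sitting at the limit of > 200000 nM in this assay, at which 3 of the 3 values shown sit. For the measured compounds named here, the one single-point step among them, a step that the two limits leave unreadable from compound 2 to compound 3, cannot be read because both ends are limits.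

Compound 4, `CCc1nnc(SCC(=O)c2ccccc2)n1N1C(=O)c2ccccc2C1=O`, differs from compound 3 by benzoyl in place of phenyl on a saturated chain carbon bound to a sulfur. Going by the values given here, no measured step bears readably on this change. Compound 1 carries the same benzoyl group on the chain carbon bound to sulfur, with methyl instead of ethyl on the core, and in this assay compound 1 gives > 200000 nM, a limit. Nothing in the shown numbers points away from the limit for compound 4. Compound 4 is thus expected to give 250000 nM in this assay, within 100000 nM to 600000 nM, most probably reported again only as a limit. The expected step is a step that the limit leaves unreadable from compound 3 to compound 4, none beyond the scatter.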

Compound 4, half-maximal inhibitory concentration: > 200000 nM
Compound 4 ended at the assay's limit; the forecaster's own chance of this, stated with the estimate: 85%; the middle value does not contradict the limit.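

In this assay compound 4 gives > 200000 nM, a limit, so no new step can be read to it from compound 1, compound 2 or compound 3: the limit of > 200000 nM in this assay, at which 4 of the 4 values shown sit.

The compounds shown leave open whether any change on the chain carbon bound to sulfur or on the shared core gives a readable value in this assay.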